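The source may hold more compounds than are shown below. What is called first, only, known or untested is meant among the compounds shown, and "the series" means these compounds.

Compound 1, `CC(C)Sc1nnc(-c2c(CN3CCC(N4CCCC4)CC3)c3ccccc3n2C)n1-c1ccccc1`, stands second highest of the three compounds measured in a physicochemical assay for lipophilicity (a lower number here means a more polar compound, a higher number a more lipophilic compound), where compound 1 gives 5.16. Its nearest neighbour is compound 2, `CC(C)Sc1nnc(-c2c(CNCCN3CCCC3)c3ccccc3n2C)n1-c1ccccc1`, which in this assay gives 4.83; the furthest is compound 3, `COc1ccc(CNCc2c(-c3nnc(SC(C)C)n3-c3ccccc3)n(C)c3ccccc23)cc1`, which gives 6.27. The steps run a number 0.33 log units lower from compound 1 to compound 2 (beyond the scatter) and a number 1.11 log units higher from compound 1 to compound 3 (beyond the scatter). Compound 4, `CC1CN(Cc2c(-c3nnc(SC(C)C)n3-c3ccccc3)n(C)c3ccccc23)CC(C)O1`, differs from compound 1 by 2,6-dimethylmorpholin-4-yl in place of 4-(pyrrolidin-1-yl)piperidin-1-yl on a saturated chain carbon bound to an aromatic carbon. Neither measured step swaps one saturated ring for another at this position, so they bear on compound 4 only loosely: the modest step to compound 2 is the closer analogy. For compound 4 in this assay a step of a number 0.06 log units lower from compound 1 to compound 4 (within the scatter) is expected, that is, none beyond the scatter, and its value is estimated at 5.1, between 4.6 and 5.6.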

Compound 4, partition coefficient: 5.13
Beside the measured number, compound 4's estimate is 0.03 log units below it; low and high end bracket the measured number.
By their numbers in this assay, from the lowest: compounds 2, 4 and 1 (each within the scatter of the next, the first and the last beyond it); then compound 3.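

In this assay, the step of a number 0.03 log units lower from compound 1 to compound 4 (within the scatter) shows that 2,6-dimethylmorpholin-4-yl, with 8 heavy atoms and one oxygen, can replace 4-(pyrrolidin-1-yl)piperidin-1-yl, with 11 heavy atoms, without a change beyond the scatter. The step of a number 0.30 log units higher from compound 2 to compound 4 (within the scatter) also stays within the scatter, so compound 4 is not set apart from either amine-bearing neighbour. The step of a number 1.14 log units lower from compound 3 to compound 4 (beyond the scatter) is large, leaving (4-methoxybenzyl)amino apart from the other three groups at this position. As far as these compounds go, whether a plain morpholin-4-yl or a piperazine would stay level with compound 4 remains open. No evidence at hand accounts for these numbers.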